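This account rests on a few compounds, and the source may have more. Where it says the series, first, only, none or still open, it means among the compounds named here.

The measured compounds:

compound 1 `O=C(Nc1cccc(-c2oc3cc(-c4ccc(F)cc4)ccc3c(=O)c2O)c1)c1ccccc1F`, 17400 nM
compound 2 `O=C(Nc1cccc(-c2oc3cc(-c4ccc(F)cc4)ccc3c(=O)c2O)c1)c1ccc(Cl)cc1`, 9140 nM
compound 3 `COc1cccc(C(=O)Nc2cccc(-c3oc4cc(-c5ccc(F)cc5)ccc4c(=O)c3O)c2)c1`, 12500 nM

All three share the same core and differ only in the aryl group on the carbonyl carbon of the amide. On a functional assay on GTL 16 cells for antiproliferative activity against GTL 16 cell line (Homo sapiens), read by CCK-8 assay, with a stated time of 72 h (on this read-out higher numbers stand for weaker inhibition and lower numbers for stronger inhibition), compound 1 gives the highest of the three numbers, yet its steps to the other two are small: a 1.9-fold lower number from compound 1 to compound 2 (0.28 log units; within the scatter) and a 1.4-fold lower number from compound 1 to compound 3 (0.14 log units; within the scatter). The remaining pair behaves the same way, a 1.4-fold higher number from compound 2 to compound 3 (0.14 log units; within the scatter), so the three aryl amides cannot be told apart on this read-out.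

Compound 4 `CCCc1ccc(C(=O)Nc2cccc(-c3oc4cc(-c5ccc(F)cc5)ccc4c(=O)c3O)c2)cc1` has not yet been measured in this assay. Relative to compound 1 the change is 4-propylphenyl in place of 2-fluorophenyl on a carbonyl carbon. The two steps that bear on it are those from compound 1 to compound 2 and from compound 1 to compound 3, each of which also exchanged the 2-fluorophenyl for a different aryl group on the same carbonyl carbon, and both stayed within the scatter. Within the data shown here, no step with a 4-propylphenyl exists among the measured compounds, so nothing points to a larger effect in either direction.

Compound 4 is therefore expected to show a 1.5-fold lower number from compound 1 to compound 4 (0.16 log units; within the scatter), a step not beyond the scatter. The estimate for compound 4 in this assay is 12000 nM, with a range from 4500 nM to 32000 nM.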

Compound 4, half-maximal inhibitory concentration: 20400 nM
The estimate for compound 4 lay 1.7-fold (0.23 log units) below the measured number; the measured number falls inside the stated range.
By their numbers in this assay, from the lowest: compounds 2, 3, 1 and 4 (each within the scatter of the next, the first and the last beyond it).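

On this assay, the 4-propylphenyl group on the carbonyl carbon, which like the 2-fluorophenyl it replaces has no hydrogen-bond donors or acceptors, gives a 1.2-fold higher number from compound 1 to compound 4 (0.07 log units; within the scatter) and a 1.6-fold higher number from compound 3 to compound 4 (0.21 log units; within the scatter), so these two exchanges do not separate compound 4 from compound 1 or compound 3. Among these compounds, the new information lies in a 2.2-fold higher number from compound 2 to compound 4 (0.35 log units; beyond the scatter), a modest change of propyl in place of chloro on an aromatic carbon and the only step among the four amides that goes beyond the scatter, which gives the set its first small separation, though one pair alone sets no trend. Nothing available accounts for this gap between compound 2 and compound 4.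

The four compounds leave open whether any group on this carbonyl carbon can move the number by much more than this modest step, since all four carry a phenyl ring with a single substituent. As far as these compounds go, an amine or a carboxylic acid on that ring, a longer chain than propyl, or a saturated ring in place of the phenyl could each test this, and the effect of each remains unknown.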